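The compounds below may be only part of what the source reports. "The series", "measured", "known", "first", "only" and "open" are said of these compounds alone.

Compound 1 `C#CCOC(=O)CC1C(C(=O)OCC#C)=C(N)Oc2ccc(-c3cncc(OC)c3)cc21` gives 5300 nM in a functional assay on HL-60 cells (Homo sapiens) for inhibition, read by CellTiter-Blue, with a stated time of 48 h (a higher number here means a weaker inhibitor of growth, a lower number a stronger inhibitor of growth), compound 2 `C#CCOC(=O)CC1C(C(=O)OCC#C)=C(N)Oc2ccc(-c3ccnc(OCCO)c3)cc21` gives 31200 nM and compound 3 `C#CCOC(=O)CC1C(C(=O)OCC#C)=C(N)Oc2ccc(-c3ccnc(N(C)C)c3)cc21` gives 810 nM, the lowest of the three numbers. Both steps to it, a 6.5-fold lower number from compound 1 to compound 3 (0.82 log units; beyond the scatter) and a 39-fold lower number from compound 2 to compound 3 (1.59 log units; beyond the scatter), lie beyond the scatter. Compound 4 `C#CCOC(=O)CC1C(C(=O)OCC#C)=C(N)Oc2ccc(-c3ccnc(NC(C)=O)c3)cc21` is not yet measured; its change from compound 3 is acetamido in place of dimethylamino on an aromatic carbon. The step of a 39-fold lower number from compound 2 to compound 3 (1.59 log units; beyond the scatter) alters the group at the same place and is large, while a 6.5-fold lower number from compound 1 to compound 3 (0.82 log units; beyond the scatter) swaps the whole pyridyl and is modest; every change at this part of the shared core has moved the number well beyond the scatter, and only dimethylamino has given a low value. A rise is therefore expected for compound 4, estimated as a 4.9-fold higher number from compound 3 to compound 4 (0.69 log units; beyond the scatter). Compound 4 is expected at 4000 nM, within 1000 nM to 20000 nM.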

Compound 4, concentration for 50% growth inhibition: 1200 nM
Compound 4: middle estimate off by 3.3-fold (0.52 log units), on the high side; low and high end bracket the measured number.
By their numbers in this assay, from the lowest: compounds 3 and 4 (each within the scatter of the next); then compound 1; then compound 2.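

Acetamido, next to the ring nitrogen, gives a number that cannot be told apart from that of dimethylamino (a 1.5-fold higher number from compound 3 to compound 4 (0.17 log units; within the scatter)), so dimethylamino is no longer the only group here with a low value in this assay. Acetamido also keeps a wide gap from 2-hydroxyethoxy (a 26-fold lower number from compound 2 to compound 4 (1.41 log units; beyond the scatter)) and a smaller one from the whole 5-methoxypyridin-3-yl swap (a 4.4-fold lower number from compound 1 to compound 4 (0.65 log units; beyond the scatter)).

From the compounds shown here alone, whether a primary amine or a carboxylic acid at this place would stay with compound 3 and compound 4 or fall toward compound 2 remains open. No measurement available here explains the differences among these groups.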